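Estimating Compound 4 from Compound 2

The source may report more compounds than this note shows. Statements on the series, on what has been measured and on what is new or still open speak of the compounds shown alone.

Compound 2 `CCNC(=O)/C=C1\CCc2ccc(F)cc21` in a functional assay on the whole organism with Mus musculus as the target, at a dose of 100 mg/kg by the intraperitoneal route (on this read-out lower numbers stand for less inhibition and higher numbers for more inhibition at the one dose given (going by the name of the read-out)), gives 100%. It stands level with compound 1 `CN(C)C(=O)/C=C1\CCc2ccc(F)cc21`, which in this assay gives 100%; together they are the highest of the three numbers, and the step of no change at the digits printed from compound 1 to compound 2 (within the scatter) lies within the scatter. Compound 3 `CCNC(=O)/C=C1\CCc2c(F)cc(F)cc21` in this assay gives 67%, so that a number 33 percentage points lower from compound 2 to compound 3 (beyond the scatter). Compound 4 `CON(C)C(=O)/C=C1\CCc2ccc(F)cc21` differs from compound 2 in one place: methoxy(methyl)amino in place of ethylamino on a carbonyl carbon. Among the measured compounds shown here, the only measured step at the carbonyl carbon, no change at the digits printed from compound 1 to compound 2 (within the scatter), was within the scatter, so a small step is expected, as a number 10 percentage points lower from compound 2 to compound 4 (within the scatter). Compound 4 is therefore estimated to give 90%, between 65% and 100%.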

Compound 4, a percentage reported as inhibition, in the whole organism at one dose (the size of the read-out at that dose, not a potency): 17%
Beside the measured number, compound 4's estimate is 73 percentage points above it; the whole stated range lies above it.
By their numbers in this assay, from the lowest: compound 4; then compound 3; then compounds 1 and 2 (each within the scatter of the next).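

In this assay, the carbonyl carbon proved sensitive to the group it carries: methoxy(methyl)amino in place of ethylamino gives a number 83 percentage points lower from compound 2 to compound 4 (beyond the scatter), and methoxy in place of methyl on the amide-type nitrogen gives a number 83 percentage points lower from compound 1 to compound 4 (beyond the scatter). The earlier agreement between dimethylamino and ethylamino therefore does not extend to every small amino group at this place, and a single methoxy for methyl exchange is enough to produce a large step. Nothing available explains this loss.

On these data alone, it remains open whether an ethoxy or hydroxy group on that nitrogen would read like methoxy or like methyl.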